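A Second Fluorine Where the First Step Was Unreadable

A few compounds are considered here, and "the series" means these few. Any claim that something is new, unique, unknown or untested is made for them only; others in the source may bear on it.

Compound 1 `CC(C)=CCC[C@@](C)(/C=C/c1ccccc1)/C=C/c1ccc(O)cc1` was tested in a functional assay on HepG2 cells (Homo sapiens) for cytotoxicity, with a stated time of 72 h; a higher number here means that more compound is needed for the effect, a lower number that less compound is needed. For compound 1 the result is only a limit, > 52000 nM. Compound 2 `CC(C)=CCC[C@](C)(/C=C/c1ccc(O)cc1)/C=C/c1cccc(F)c1` differs from it by fluoro in place of hydrogen on an aromatic carbon. For compound 2 the result is likewise a limit, > 52000 nM. The step that the two limits leave unreadable from compound 1 to compound 2 is therefore not readable. Compound 3 `C=C[C@@](C)(/C=C/c1ccc(Nc2ccc(F)cc2)cc1)CCC=C(C)C` rests on a different core; the difference between the two cores is not broken down here. For compound 3 this assay again gives only a limit, > 52000 nM. Compound 4 `C=C[C@@](C)(/C=C/c1ccc(Nc2ccc(F)c(F)c2)cc1)CCC=C(C)C` differs from compound 3 by fluoro in place of hydrogen on an aromatic carbon, the same kind of change as that from compound 1 to compound 2, but here the place is also ortho to a fluoro group. Because (the limit of > 52000 nM in this assay, at which 3 of the 3 values shown sit), a limit is expected once more, with the step that the limit leaves unreadable from compound 3 to compound 4 estimated as near nothing. The estimate for compound 4 is 100000 nM, expected between 52000 nM and 300000 nM.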

Compound 4, half-maximal effective concentration: > 52000 nM
Compound 4 was reported as a limit; the forecaster's own chance of this, stated with the estimate: 90%; the middle value lies beyond the limit too.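

Going by these compounds alone, compound 3 and compound 4 are both reported only as limits in this assay, and no step between them can be read. The compounds shown leave open what concentration, if any, produces the effect, and whether the added fluoro changes it.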